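Sulfonyl aryl variation on the shared core

A few compounds are considered here, and "the series" means these few. Any claim that something is new, unique, unknown or untested is made for them only; others in the source may bear on it.

Compound 3 `CC(C)Cc1cc(CNS(=O)(=O)c2ccc3ccccc3c2)nn1-c1ccccc1` gives the lowest number of the three measured, 3300 nM in a functional assay on HeLa cells for antagonist activity at 5-hydroxytryptamine receptor 6 (Homo sapiens), read by HTRF and cAMP accumulation, with stated times of 10 min and 30 min; on this read-out lower numbers stand for stronger inhibition and higher numbers for weaker inhibition. Compound 1 `CC(C)Cc1cc(CNS(=O)(=O)c2cccc(Cl)c2)nn1-c1ccccc1` gives 10900 nM and compound 2 `CC(C)Cc1cc(CNS(=O)(=O)c2ccc(C(C)(C)C)cc2)nn1-c1ccccc1` gives 8780 nM; a 1.2-fold lower number from compound 1 to compound 2 (0.09 log units; within the scatter). The two steps onto compound 3 were modest: a 3.3-fold lower number from compound 1 to compound 3 (0.52 log units; beyond the scatter) and a 2.7-fold lower number from compound 2 to compound 3 (0.42 log units; beyond the scatter). Compound 4 `Cc1c(Cl)cccc1S(=O)(=O)NCc1cc(CC(C)C)n(-c2ccccc2)n1` differs from compound 3 by 3-chloro-2-methylphenyl in place of naphthalen-2-yl on a sulfonyl sulfur. Among the measured compounds shown here, this returns to a single six-membered aromatic ring bearing a chlorine, so the steps that bear on it are those from compound 1 and from compound 2 to compound 3, read in reverse; a step beyond the scatter toward a higher number is therefore expected. For compound 4 the expected step is a 2.4-fold higher number from compound 3 to compound 4 (0.38 log units; beyond the scatter). Compound 4 is estimated at 8000 nM, between 3000 nM and 25000 nM.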

Compound 4, half-maximal inhibitory concentration: 4010 nM
For compound 4 the middle estimate is 2.0-fold (0.30 log units) above the measured one, within the range that was stated.
By their numbers in this assay, from the lowest: compounds 3 and 4 (each within the scatter of the next); then compounds 2 and 1 (each within the scatter of the next).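

In this assay, one six-membered aromatic ring on the sulfonyl sulfur serves as well as the two rings of naphthalen-2-yl (a 1.2-fold higher number from compound 3 to compound 4 (0.08 log units; within the scatter)). Methyl in place of hydrogen on an aromatic carbon gives a step beyond the scatter (a 2.7-fold lower number from compound 1 to compound 4 (0.43 log units; beyond the scatter)), and 3-chloro-2-methylphenyl also separates from 4-(tert-butyl)phenyl (a 2.2-fold lower number from compound 2 to compound 4 (0.34 log units; beyond the scatter)). No measurement at hand accounts for these steps.

Open, from the compounds shown here alone, is whether an amine or a carboxylic acid on the sulfonyl aryl ring would shift the number further. Also open, going by these compounds, is whether the methyl would give this step without the chlorine.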